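One Added Methoxy Group and Measured Lipophilicity

This account rests on a few compounds, and the source may have more. Where it says the series, first, only, none or still open, it means among the compounds named here.

Compound 1 `COc1cc(O)c(C(=O)/C=C/c2cc(OC)c(OC)c(OC)c2)cc1OC`, compound 2 `COc1ccc(C(=O)/C=C/c2cc(OC)c(OC)c(OC)c2)c(O)c1` and compound 3 `COc1cccc(/C=C/C(=O)c2cc(OC)ccc2O)c1` have been measured in a physicochemical assay for lipophilicity; a lower number here means a more polar compound, a higher number a more lipophilic compound. Compound 1 gives 3.5, compound 2 gives 3.49, and compound 3 gives 3.87, the highest of the three; the difference between the core of compound 3 and that of compound 2 is not broken down here. Compound 4 `COc1ccc(O)c(C(=O)/C=C/c2ccc(OC)c(OC)c2)c1` is not yet measured. It differs from compound 3 by methoxy in place of hydrogen on an aromatic carbon. The same kind of change separates compound 2 from compound 1, namely (methoxy in place of hydrogen on an aromatic carbon), though there the site is meta to a large group and para to a hydroxy group, while in compound 4 it is para to a large group. That earlier change gave a number 0.01 log units higher from compound 2 to compound 1 (within the scatter). Because a number 0.01 log units higher from compound 2 to compound 1 (within the scatter) was so small, the expected step is similarly small: a number 0.03 log units higher from compound 3 to compound 4 (within the scatter). Compound 4 is therefore estimated at 3.9, between 3.5 and 4.3.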

Compound 4, partition coefficient: 3.52
Compound 4: the middle estimate sits 0.38 log units above what was measured; the measured number falls inside the stated range.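

Methoxy in place of hydrogen on an aromatic carbon gave a number 0.35 log units lower from compound 3 to compound 4 (beyond the scatter) in this assay while the same kind of change gave a number 0.01 log units higher from compound 2 to compound 1 (within the scatter) on another core. In these two cases, then, the size of the step did not carry over from one core to the other, so one step cannot be assumed to predict the next in this series. Within the data shown here, with only two examples, which differ in both core and site, the data cannot separate the role of the core from that of the site, and nothing here gives a reason for the difference.

As far as these compounds go, whether this step would recur at the same site on a third core remains open. So does how an amine, a carboxylic acid or a longer chain at that site would compare with methoxy.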